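The source may report more compounds than this note shows. Statements on the series, on what has been measured and on what is new or still open speak of the compounds shown alone.

Compounds measured so far:

Compound 1, `COc1cc(N(C)CCN(C)C)c(NC(=O)/C=C\C(C)C)cc1Nc1nccc(-c2cn(C)c3ccccc23)n1`, 4390 nM
Compound 2, `CCC/C=C\C(=O)Nc1cc(Nc2nccc(-c3cn(C)c4ccccc34)n2)c(OC)cc1N(C)CCN(C)C`, 431 nM
Compound 3, `COc1cc(N(C)CCN(C)C)c(NC(=O)/C=C\C(C)C)cc1Nc1ncc(C#N)c(-c2cn(C)c3ccc(F)cc23)n1`, 2840 nM

The three measured compounds were examined in a functional assay on HepG2 cells (Homo sapiens) for antiproliferative activity, read by MTT assay, with a stated time of 72 h; a lower number here means a stronger inhibitor, a higher number a weaker inhibitor. Compound 1 and compound 2 share one core, and the only difference between them is propyl in place of isopropyl on a double-bonded chain carbon bound to a double-bonded chain carbon. That single change gave a 10-fold lower number from compound 1 to compound 2 (1.01 log units; beyond the scatter), so compound 2 is the one of these three with the lowest number.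

Compound 3 is built on a different core from compound 1; the difference between the two cores is not broken down here. With the isopropyl-bearing chain in place, compound 3 gives 2840 nM, and its gap to compound 1 lies within the usual scatter, so the two cannot be ranked against each other on this evidence.

Compound 4, `CCC/C=C\C(=O)Nc1cc(Nc2ncc(C#N)c(-c3cn(C)c4ccc(F)cc34)n2)c(OC)cc1N(C)CCN(C)C`, has not yet been measured. It differs from compound 3 by propyl in place of isopropyl on a double-bonded chain carbon bound to a double-bonded chain carbon, which is the same change that was made from compound 1 to compound 2. On that basis, and resting on the step of a 10-fold lower number from compound 1 to compound 2 (1.01 log units; beyond the scatter), compound 4 is expected to give 350 nM in this assay, a step of an 8.1-fold lower number from compound 3 to compound 4 (0.91 log units; beyond the scatter). A single earlier instance is all that supports this, so the range 120 nM to 1200 nM is estimated to cover the likely outcome for compound 4.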

Compound 4, half-maximal inhibitory concentration: 2010 nM
Estimate against measurement, compound 4: 5.7-fold (0.76 log units) below, outside the stated range (above it).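

In this assay, putting propyl in place of isopropyl on a double-bonded chain carbon bound to a double-bonded chain carbon gave a 1.4-fold lower number from compound 3 to compound 4 (0.15 log units; within the scatter), so compound 3 and compound 4 cannot be ranked against each other and the two chains cannot be told apart on this core. The change therefore did not carry over from the core of compound 1 to the core of compound 3 with the size it had on the first core, and the two steps do differ: the same change on two cores in this assay, a 10-fold lower number (1.01 log units; beyond the scatter) from compound 1 to compound 2 and a 1.4-fold lower number (0.15 log units; within the scatter) from compound 3 to compound 4, 7.2-fold (0.86 log units) apart, beyond the scatter of two such steps This does not show which feature of the core of compound 3 is responsible, as that core carries both a nitrile and a fluorine that the core of compound 1 lacks, and each core is represented by a single pair of compounds.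

The compounds shown leave open whether the nitrile alone or the fluorine alone is enough to produce this difference between the two steps. They also leave open how a longer chain such as pentyl, or a chain ending in an amine, would behave in the same place on either core.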